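Compound 4: replacing the aryl group of compound 3

The source may hold more compounds than are shown below. What is called first, only, known or untested is meant among the compounds shown, and "the series" means these compounds.

In an ADME assay on J774.A1 cells (Mus musculus) for cytotoxicity, read by MTT assay, with a stated time of 48 h (a lower number here means that less compound is tolerated, a higher number that more compound is tolerated), compound 1 `O=C(NCc1ccccc1)c1c([N+](=O)[O-])noc1-c1ccc(Cl)cc1` carries no number ("not determined" (no result reported)), compound 2 `O=C(NCc1cccc(Br)c1)c1c([N+](=O)[O-])noc1-c1ccc(Cl)cc1Cl` gives 71200 nM and compound 3 `COC(=O)c1c(NCCCNc2ccnc3cc(Cl)ccc23)noc1-c1ccc([N+](=O)[O-])cc1` gives 107000 nM so these two numbers lie within the scatter of each other. That pair is all the quantitative footing available for the series.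

Compound 4 `COC(=O)c1c(NCCCNc2ccnc3cc(Cl)ccc23)noc1-c1ccc(Cl)cc1Cl` keeps the methoxycarbonyl group and the large group of compound 3 but has 2,4-dichlorophenyl in place of 4-nitrophenyl on an aromatic carbon. Going by the values given here, no measured pair differs in one place, so this change has no direct precedent. Compound 2 also bears 2,4-dichlorophenyl and gives 71200 nM in this assay but it differs from compound 3 in other places too, which makes it only a loose guide. No step beyond the scatter is therefore expected: the estimated 1.4-fold lower number from compound 3 to compound 4 (0.15 log units; within the scatter) stays within it. Compound 4 is expected at 75000 nM (estimated range 28000 nM to 170000 nM).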

Compound 4, half-maximal cytotoxic concentration: 31100 nM
The estimate for compound 4 lay 2.4-fold (0.38 log units) above the measured number; measured number inside the range.
By their numbers in this assay, from the lowest: compound 4; then compounds 2 and 3 (each within the scatter of the next).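

In this assay, going by these compounds alone, the aryl group on the aromatic carbon next to the ring oxygen proves to matter, a point no earlier pair could test: 2,4-dichlorophenyl in place of 4-nitrophenyl gives a 3.4-fold lower number from compound 3 to compound 4 (0.54 log units; beyond the scatter) with the methoxycarbonyl group and the large group held constant. At this position, less compound is tolerated with 2,4-dichlorophenyl than with 4-nitrophenyl, although this rests on a single pair. Nothing available explains why the number moves at this position.

This one exchange removes the nitro group and adds two chlorines together, so it cannot show which part accounts for the step. Unsubstituted phenyl, 4-chlorophenyl or 4-methoxyphenyl at the same position, with the rest of compound 3 kept, would separate those parts, and whether the step carries over to other groups in place of methoxycarbonyl remains open.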